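Cytotoxicity notes: from compound 3 to compound 4

The source may hold more compounds than are shown below. What is called first, only, known or untested is meant among the compounds shown, and "the series" means these compounds.

Measured so far in an ADME assay on CCRF-HSB-2 cells (Homo sapiens) for cytotoxicity, with a stated time of 7 days; on this read-out higher numbers stand for lower toxicity in this test and lower numbers for higher toxicity in this test:
compound 1, `CCCOc1nc(N)nc2c1ncn2/C=C1/CC1(CO)CO`, a limit of the assay at > 20000 nM.
compound 2, `CCCCNc1nc(N)nc2c1ncn2/C=C1/CC1(CO)CO`, a limit of the assay at > 20000 nM.
compound 3, `CCCCCCCCSc1nc(N)nc2c1ncn2/C=C1/CC1(CO)CO`, 60000 nM.

Among the compounds with values here, compound 3 gives the only number in this assay; the other two values are limits, and the steps a step that the limit leaves unreadable from compound 1 to compound 3 and a step that the limit leaves unreadable from compound 2 to compound 3 are therefore not readable, nor is a step that the two limits leave unreadable from compound 1 to compound 2, since the limit of > 20000 nM in this assay, at which 2 of the 3 values shown sit, is where compound 1 and compound 2 sit. Compound 4, `CCCCOc1nc(N)nc2c1ncn2/C=C1/CC1(CO)CO`, differs from compound 3 by butoxy in place of octylsulfanyl on an aromatic carbon. Within the data shown here, no measured step bears readably on this change, so the expectation for compound 4 rests on compound 3 alone together with the two limits. Compound 4 is expected at 40000 nM, between 15000 nM and 120000 nM, a step of a 1.5-fold lower number from compound 3 to compound 4 (0.18 log units; within the scatter) that is expected to stay within the scatter.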

Compound 4, half-maximal cytotoxic concentration: > 20000 nM
Compound 4 gave a limit, no number (the forecaster's own chance of this, stated with the estimate: 60%); the middle value is on the limit's open side.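

Compound 4 gives only a limit in this assay, so no step from compound 1, compound 2 or compound 3 to compound 4 can be read: the limit of > 20000 nM in this assay, at which 3 of the 4 values shown sit.

The compounds shown leave open whether propoxy, butylamino and butoxy differ at all from octylsulfanyl in this assay.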